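Swapping an aryl group for a thiazole on the piperazine

A few compounds are considered here, and "the series" means these few. Any claim that something is new, unique, unknown or untested is made for them only; others in the source may bear on it.

Three compounds share one core. Compound 1 `O/N=C(\CCN1CCN(c2nccs2)CC1)c1ccccc1` gives 44% in a functional assay on HEK293 cells with D(4) dopamine receptor (Homo sapiens) as the target, read by FLIPR; a higher number here means a larger maximal response, a lower number a smaller maximal response. Compound 2 `CCO/N=C(\CCN1CCN(c2ccccc2C#N)CC1)c1ccccc1` gives 82%, and compound 3 `CCO/N=C(\CCN1CCN(c2cccc(OCC)c2)CC1)c1ccccc1` gives 84%, the highest of the three numbers, though compound 2 lies within the scatter of it. Compound 4 `CCO/N=C(\CCN1CCN(c2nccs2)CC1)c1ccccc1` is not yet measured; it differs from compound 3 as follows: 1,3-thiazol-2-yl in place of 3-ethoxyphenyl on an amine nitrogen in a ring. Within the data shown here, the one step that touches this position, a number 2 percentage points higher from compound 2 to compound 3 (within the scatter), was within the scatter, but it exchanged one six-membered aromatic ring for another. Among the measured compounds shown here, the only compound with the 1,3-thiazol-2-yl group, compound 1, also carries a different oxime substituent, so its lower value is not a clean guide. For compound 4 a somewhat lower response is expected, 66%, within 42% to 90%, an estimated step of a number 18 percentage points lower from compound 3 to compound 4 (beyond the scatter).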

Compound 4, largest response reached (reported as efficacy), in percent of the reference or control that the assay uses: 72%
The estimate for compound 4 lay 6 percentage points below the measured number, and the stated range covers the measured number.
By their numbers in this assay, from the lowest: compound 1; then compounds 4, 2 and 3 (each within the scatter of the next, the first and the last beyond it).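

In this assay, 1,3-thiazol-2-yl on the amine nitrogen gives a number 12 percentage points lower from compound 3 to compound 4 (beyond the scatter) when it replaces 3-ethoxyphenyl and a number 10 percentage points lower from compound 2 to compound 4 (within the scatter) when it replaces 2-cyanophenyl, so a five-membered aromatic ring with 2 hetero atoms retains a substantial response at this position. With that ring held constant, ethyl in place of hydrogen on the oxygen gives a number 28 percentage points higher from compound 1 to compound 4 (beyond the scatter), showing that the low value of compound 1 cannot be attributed to the thiazole alone. Nothing available here explains either change.

Going by these compounds, it remains open how a pyridine ring would compare on the same nitrogen, and whether a propyl chain on the oxygen would extend the rise seen with ethyl.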